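The compounds below may be only part of what the source reports. "The series", "measured", "known", "first", "only" and "open" are said of these compounds alone.

Measured compounds and their values:
- compound 1, `COc1ccc(-n2nc(C(=O)NCC(=O)Nc3nc4ccc(C)cc4s3)c3ccccc3c2=O)cc1`, gives 25 nM
- compound 2, `COc1ccc(-n2nc(C(=O)NCC(=O)Nc3nc4ccccc4s3)c3ccccc3c2=O)cc1`, gives 25000 nM
- compound 3, `O=C(CNC(=O)c1nn(-c2ccccc2)c(=O)c2ccccc12)Nc1nc2ccc(Cl)cc2s1`, gives 30 nM

These values come from an assay on L cells for inhibition of Protein-serine O-palmitoleoyltransferase porcupine (Mus musculus), read by reporter gene assay, with a stated time of 24 h; a lower number here means that less compound is needed, a higher number that more compound is needed for the effect. Compound 3 stands second highest of the three numbers; its nearest neighbour is compound 1, whose value lies within the scatter of that of compound 3, and the furthest is compound 2, well beyond the scatter. Within the data shown here, the only step among the measured pairs is a 1000-fold higher number from compound 1 to compound 2 (3.00 log units; beyond the scatter), which concerns a different place in the molecule and does not directly bear on the change now considered.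

Compound 4, `COc1ccc(-n2nc(C(=O)NCC(=O)Nc3nc4ccc(Cl)cc4s3)c3ccccc3c2=O)cc1`, is not yet measured. It differs from compound 3 by methoxy in place of hydrogen on an aromatic carbon. Among the measured compounds shown here, no measured pair isolates this change. Compounds 1 and 3 both carry a halogen or methyl on the same ring and differ in the presence of this methoxy group among other things, yet their values lie within the scatter of each other, so little effect is expected. The estimated step is a 1.2-fold lower number from compound 3 to compound 4 (0.08 log units; within the scatter). Compound 4 is therefore expected to give about 25 nM, within a range from 8 nM to 80 nM.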

Compound 4, half-maximal effective concentration: 15 nM
Compound 4: the middle estimate sits 1.7-fold (0.22 log units) above what was measured; measured number inside the range.
By their numbers in this assay, from the lowest: compounds 4, 1 and 3 (each within the scatter of the next); then compound 2.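

In this assay, methoxy in place of hydrogen on an aromatic carbon, para to a large group, gives a 2.0-fold lower number from compound 3 to compound 4 (0.30 log units; within the scatter) and so, taken alone, the change from phenyl to 4-methoxyphenyl stays inside the usual scatter. With that 4-methoxyphenyl group held constant, chloro in place of hydrogen on an aromatic carbon gives a 1700-fold lower number from compound 2 to compound 4 (3.22 log units; beyond the scatter) and is a large step beyond the scatter. Chloro in place of methyl at that same carbon gives a 1.7-fold lower number from compound 1 to compound 4 (0.22 log units; within the scatter) and so the two groups cannot be told apart here, while nothing available explains any of these steps.

The compounds shown leave open whether a larger ether such as ethoxy, an amine or a carboxylic acid would be tolerated in place of the methoxy on the phenyl ring. They also leave open whether the large gain seen with chloro or methyl over hydrogen would hold on the plain phenyl compound, and how groups such as fluoro or nitrile would behave at that carbon.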